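The source may hold more compounds than are shown below. What is called first, only, known or untested is meant among the compounds shown, and "the series" means these compounds.

Compound 2 `Oc1cccc(-c2cc(-c3ccc(Cl)cc3)nc(-c3ccccn3)c2)c1` gives 30% in an assay on isolated protein for inhibition of DNA topoisomerase 1 (Homo sapiens), with a stated time of 30 min, tested at 100 uM; on this read-out higher numbers stand for a stronger effect at the one concentration tested and lower numbers for a weaker effect; compound 1 `Oc1cccc(-c2cc(-c3ccc(Cl)cc3)nc(-c3cccs3)c2)c1` gives 15.1%. For the measured compounds named here, compound 2 thus stands highest of the two numbers, and the only step yet seen, a number 14.9 percentage points higher from compound 1 to compound 2 (beyond the scatter), moved up. Compound 3 `Oc1cccc(-c2cc(-c3ccccc3)nc(-c3ccc(Cl)cc3)c2)c1` is not yet measured. Going by the values given here, its change from compound 2, (phenyl in place of pyridin-2-yl on an aromatic carbon), is of a different kind: no measured step swaps a heteroaryl ring for a carbon-only ring, so the single step bears on it only loosely. A drift downward toward compound 1 seems as likely as none beyond the scatter; the expected step is a number 9 percentage points lower from compound 2 to compound 3 (within the scatter). For compound 3 the estimate is 21%, within 6% to 38%.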

Compound 3, a percentage reported as inhibition, at one concentration (the size of the read-out at that concentration, not a potency): 7.1%
Beside the measured number, compound 3's estimate is 13.9 percentage points above it, within the range that was stated.
By their numbers in this assay, from the lowest: compounds 3 and 1 (each within the scatter of the next); then compound 2.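

At the aromatic carbon next to the ring nitrogen, phenyl in place of pyridin-2-yl gives (a number 22.9 percentage points lower from compound 2 to compound 3 (beyond the scatter)) in this assay, so pyridin-2-yl now stands apart from a carbon-only ring as well as from thiophen-2-yl. Phenyl in place of thiophen-2-yl gives (a number 8 percentage points lower from compound 1 to compound 3 (within the scatter)), so these two rings cannot be ordered at this carbon. No supporting measurement accounts for the gap left by pyridin-2-yl.

Still open, on these data alone, is whether the ring nitrogen must sit where pyridin-2-yl places it, a question that pyridin-3-yl or pyridin-4-yl at this carbon would address. Also open, as far as these compounds go, is how a non-aromatic group such as morpholin-4-yl would read here.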